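This account rests on a few compounds, and the source may have more. Where it says the series, first, only, none or still open, it means among the compounds named here.

Measured so far in a functional assay on RAW264.7 cells (Mus musculus) for inhibition, with stated times of 2 h and 24 h; a lower number here means a stronger inhibitor, a higher number a weaker inhibitor:
- compound 1 `COc1ccc(CSC2c3cc(OC)cc(OC)c3[C@@H](c3ccc(OC)cc3)[C@@H]2c2cc(OC)cc(OC)c2)cc1`: 12500 nM
- compound 2 `COc1ccc(CSC2c3cc(OC)cc(OC)c3[C@@H](c3ccccc3)[C@@H]2c2cc(OC)cc(OC)c2)cc1`: > 200000 nM (a limit)
- compound 3 `COc1ccc([C@@H]2c3c(OC)cc(OC)cc3C(SCc3ccc(Cl)cc3)[C@H]2c2cc(OC)cc(OC)c2)cc1`: > 200000 nM (a limit)

Compound 2 has no numerical value, and its result of > 200000 nM is a limit. This is the same limit reached by compound 3, as the limit of > 200000 nM in this assay, at which 2 of the 3 values shown sit, records.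

Compound 4 `COc1ccc(C(O)C2c3cc(OC)cc(OC)c3[C@@H](c3ccccc3)[C@@H]2c2cc(OC)cc(OC)c2)cc1` departs from compound 2 at a single place: hydroxy(4-methoxyphenyl)methyl in place of (4-methoxybenzyl)sulfanyl on a saturated ring carbon. For the measured compounds named here, no measured step covers this exchange on a saturated ring carbon. The two measured steps, an at least 16-fold higher number from compound 1 to compound 2 (1.20 log units; beyond the scatter) and an at least 16-fold higher number from compound 1 to compound 3 (1.20 log units; beyond the scatter), were both large, but both were changes on an aromatic carbon. The first bears most closely, since compound 4 keeps the phenyl group that this step introduced. A return to the level of compound 1 at 12500 nM is therefore not expected.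

The expected change is no step beyond the scatter, estimated as an at least 1.3-fold lower number from compound 2 to compound 4 (0.12 log units; that floor lies within the scatter). For compound 4 the estimated value is 150000 nM, with an expected range of 30000 nM to 300000 nM.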

Compound 4, half-maximal inhibitory concentration: 16500 nM
Estimate against measurement, compound 4: 9.1-fold (0.96 log units) above, outside the stated range (below it).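

In this assay the exchange on the saturated ring carbon gives an at least 12-fold lower number from compound 2 to compound 4 (1.08 log units; beyond the scatter), the only step shown that runs toward a stronger inhibitor, and it occurs with the phenyl group kept. Inhibition in a compound bearing that phenyl group can therefore be recovered by a change on the saturated ring carbon alone, with an entering group that matches the leaving one in size and aromatic ring but brings a hydrogen-bond donor and loses the sulfur. Compound 2 stands at a limit and not at a number, so the step is only a floor: the limit of > 200000 nM in this assay, at which 2 of the 4 values shown sit.

The compounds shown do not separate the part played by the hydroxy group from that of the carbon linkage replacing sulfur. From the compounds shown here alone, an amine or a ketone carbonyl in place of that hydroxy group remains open, as does the same exchange on the core of compound 1.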